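The source may report more compounds than this note shows. Statements on the series, on what has been measured and on what is new or still open speak of the compounds shown alone.

In a functional assay on brain (Rattus norvegicus, strain Wistar) for inhibition (a lower number here means a stronger inhibitor, a higher number a weaker inhibitor), compound 1 `CCCCc1ccc(-c2c(C)[nH]c(=O)n2C2CCCCC2)cc1` gives 27100 nM, compound 2 `COc1ccc(-c2c(C)[nH]c(=O)n2C2CCCCC2)cc1` gives 20400 nM and compound 3 `CCCCCCCCc1ccc(-c2c(C)[nH]c(=O)n2C2CCCCC2)cc1` gives 10300 nM. The closest gap to compound 3 is a 2.0-fold lower number from compound 2 to compound 3 (0.30 log units; within the scatter), and the widest is a 2.6-fold lower number from compound 1 to compound 3 (0.42 log units; beyond the scatter). Compound 4 `Cc1[nH]c(=O)n(C2CCCCC2)c1-c1ccc(OCc2ccccc2)cc1` changes one group: benzyloxy in place of octyl on an aromatic carbon. Swaps at this place have moved the number little so far, with a 1.3-fold lower number from compound 1 to compound 2 (0.12 log units; within the scatter) and the same gap for the methoxy-to-octyl swap, and only the butyl extension passes the scatter, modestly. Among the measured compounds shown here, no measured compound carries a ring in this group, so the guide is indirect. The expected step, a 1.4-fold higher number from compound 3 to compound 4 (0.13 log units; within the scatter), is no step beyond the scatter. For compound 4 the estimated value is 14000 nM, with an expected range of 6500 nM to 30000 nM.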

Compound 4, half-maximal inhibitory concentration: 8300 nM
The estimate for compound 4 lay 1.7-fold (0.23 log units) above the measured number; the range from low to high includes it.
By their numbers in this assay, from the lowest: compounds 4, 3, 2 and 1 (each within the scatter of the next, the first and the last beyond it).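

In this assay, among the compounds shown here, this position now carries a ring for the first time, and benzyloxy in place of octyl gives a 1.2-fold lower number from compound 3 to compound 4 (0.09 log units; within the scatter) with no change that can be read. Phenyl added to the methoxy group gives a 2.5-fold lower number from compound 2 to compound 4 (0.39 log units; beyond the scatter) and benzyloxy in place of butyl gives a 3.3-fold lower number from compound 1 to compound 4 (0.51 log units; beyond the scatter) as modest steps, so a ring in this group costs nothing in this small set. No supporting evidence bears on this result.

On these data alone, it remains open whether the oxygen or the ring matters more, and whether an amine or a carboxylic acid on the benzyl ring would shift the number.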